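Lengthening the chain from compound 3 to compound 4

This account rests on a few compounds, and the source may have more. Where it says the series, first, only, none or still open, it means among the compounds named here.

Measured in a functional assay on A549 cells (Homo sapiens) for antiproliferative activity, read by MTT assay, with a stated time of 48 h; a lower number here means a stronger inhibitor, a higher number a weaker inhibitor:
- compound 1 `CCCCCCC1(O)C(=O)Nc2ccc(Nc3ccc(C)cc3)cc21`: 12100 nM
- compound 2 `CCCCC1(O)C(=O)Nc2ccc(Nc3ccc(Cl)cc3)cc21`: 2800 nM
- compound 3 `CCCCCC1(O)C(=O)Nc2ccc(Nc3ccc(Cl)cc3)cc21`: 1900 nM

Compound 3 and compound 2 lie within the scatter of each other, so neither can be ranked over the other. Compound 1 stands apart from both, with a clearly higher number than compound 3.

Next in the series is compound 4 `CCCCCCC1(O)C(=O)Nc2ccc(Nc3ccc(Cl)cc3)cc21`, which differs from compound 3 as follows: methyl in place of hydrogen on a saturated chain carbon, five bonds along the chain from a saturated ring carbon. In words, this is methyl in place of hydrogen on a saturated chain carbon, five bonds along the chain from a saturated ring carbon.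

Among the measured compounds shown here, only one measured step bears directly on this change: a 1.5-fold lower number from compound 2 to compound 3 (0.17 log units; within the scatter). It is the same kind of change, methyl in place of hydrogen on a saturated chain carbon, but four bonds along the chain from a saturated ring carbon. For the measured compounds named here, compound 1 shares its chain with compound 4 but differs from it elsewhere, and no measured step isolates that difference, so it sets no size for this change. With a single small step as the guide, no change beyond the scatter is expected in this assay, though one step is thin evidence. The expected step is a 1.1-fold lower number from compound 3 to compound 4 (0.02 log units; within the scatter). For compound 4 the estimated value is 1800 nM, with an expected range of 800 nM to 4000 nM.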

Compound 4, half-maximal inhibitory concentration: 5400 nM
Estimate against measurement, compound 4: 3.0-fold (0.48 log units) below; the measured number lies above the stated range.
By their numbers in this assay, from the lowest: compounds 3, 2 and 4 (each within the scatter of the next, the first and the last beyond it); then compound 1.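

Working from this assay the added methyl at this place, five bonds along the chain from a saturated ring carbon, gives a 2.8-fold higher number from compound 3 to compound 4 (0.45 log units; beyond the scatter) and is the first chain change in the series to pass the scatter, whereas the same change four bonds along gave only a 1.5-fold lower number from compound 2 to compound 3 (0.17 log units; within the scatter) and could not be ranked. Among the compounds shown here, the chain series therefore shows no steady trend: the ethyl in place of hydrogen that spans both additions gives a 1.9-fold higher number from compound 2 to compound 4 (0.29 log units; within the scatter) and stays within the scatter, so the only readable chain step is the one that ends at compound 4. For the compounds shown here, with the chain held constant, chloro in place of methyl on an aromatic carbon gives a 2.2-fold lower number from compound 1 to compound 4 (0.35 log units; beyond the scatter) and is the first isolated reading at the aromatic carbon, a modest step in the opposite direction to the chain step.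

Still open, going by these compounds, is whether a longer chain than that of compound 4 would carry the number further up, and whether an amine or a carboxylic acid at the chain end would read like the plain chain. Nothing at hand accounts for the step at this position.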